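Ethyl to methyl at the chain carbon: expected effect on seizure protection

The source may report more compounds than this note shows. Statements on the series, on what has been measured and on what is new or still open speak of the compounds shown alone.

Measured so far:
- compound 1, `CC(C(=O)N1CCN(c2ccccc2Cl)CC1)N1C(=O)CCC1=O`: 0%
- compound 2, `CCC(C(=O)N1CCN(c2cccc(Cl)c2)CC1)N1C(=O)CCC1=O`: 25%

In a functional assay on the whole organism (strain Swiss) with Mus musculus as the target, in the maximal electroshock model, with a stated time of 2 h, at a dose of 300 mg/kg by the intraperitoneal route (on this read-out lower numbers stand for a weaker effect and higher numbers for a stronger effect at the one dose given), compound 2 gives 25% and stands highest of the two numbers; the nearest, compound 1, lies lower by a gap beyond the scatter. Among the measured compounds shown here, compound 1 and compound 2 differ in more than one place, so their two values show only that the pair sits apart, not which change carries the gap.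

Compound 3, `CC(C(=O)N1CCN(c2cccc(Cl)c2)CC1)N1C(=O)CCC1=O`, has not been measured in this assay . It differs from compound 2 by hydrogen in place of methyl on a saturated chain carbon, two bonds along the chain from an amide-type nitrogen in a ring and a carbonyl carbon. Compound 1 carries the same methyl chain as compound 3. In this assay compound 1 gives 0%. Compound 1 also differs from compound 3 elsewhere, so that value cannot be read directly onto compound 3.

For the measured compounds named here, with no single-change step between measured compounds to lean on, the expectation is a step down from compound 2 to compound 3 of modest size, close to the scatter edge. Compound 3 is thus estimated at 10%, within 0% to 30%, an expected step of a number 15 percentage points lower from compound 2 to compound 3 (beyond the scatter).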

Compound 3, a percentage reported as activity, at one dose (the size of the read-out at that dose, not a potency): 50%
Compound 3: the middle estimate sits 40 percentage points below what was measured, outside the stated range (above it).
By their numbers in this assay, from the lowest: compound 1; then compound 2; then compound 3.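

In this assay, among the compounds shown here, hydrogen in place of methyl on the saturated chain carbon, two bonds along the chain from an amide-type nitrogen in a ring and a carbonyl carbon, gives a number 25 percentage points higher from compound 2 to compound 3 (beyond the scatter), the first single-place reading at this position, and here the ethyl to methyl change raises the read-out at the one dose given. With the methyl chain held constant, 3-chlorophenyl in place of 2-chlorophenyl on an amine nitrogen in a ring gives a number 50 percentage points higher from compound 1 to compound 3 (beyond the scatter), so the chlorine placement on the phenyl also carries a large step of its own, which the earlier pair of compounds could not isolate. No measurement on hand accounts for either step.

Still open, going by these compounds, is how the chain position reads beyond ethyl and methyl, for example with a longer chain such as propyl or with a carboxylic acid on that carbon. Also open, on these data alone, is whether the ethyl to methyl step keeps its direction and size with 2-chlorophenyl in place of 3-chlorophenyl, and how a phenyl ring carrying an amine would read at this single dose.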